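Benzoxaborole Anilides: Extending the Amide Substituent

The compounds below may be only part of what the source reports. "The series", "measured", "known", "first", "only" and "open" are said of these compounds alone.

Compound 1 `CCNC(=O)CCc1cccc2c1B(O)OC2`, compound 2 `CC(C)c1cccc(NC(=O)CCc2cccc3c2B(O)OC3)c1` and compound 3 `O=C(CCc1cccc2c1B(O)OC2)Nc1ccc2ccccc2c1` share one core and differ only in the amide partner. In a functional assay on HCT-116 cells (Homo sapiens) for antiproliferative activity, read by MTT assay, with a stated time of 72 h (a lower number here means a stronger inhibitor, a higher number a weaker inhibitor), compound 1 gives > 100000 nM, a limit of the assay rather than a number. In this assay compound 2 gives 1600 nM. In this assay compound 3 gives 1700 nM.

Among the two numbers recorded, compound 2 has the lower one, with compound 3 so close that the two are within the scatter of repeated measurements; no order between them can be claimed. The one limit, (the limit of > 100000 nM in this assay, at which 1 of the 3 values shown sits), belongs to compound 1 alone.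

Compound 4 `CSc1cccc(-c2cccc(NC(=O)CCc3cccc4c3B(O)OC4)c2)c1` is not yet measured. It differs from compound 2 in one place: 3-(methylsulfanyl)phenyl in place of isopropyl on an aromatic carbon. For the measured compounds named here, no pair of measured compounds differing in a single position is available, so the size of this step is not known from the data. Both anilides carrying a larger aromatic substituent, compound 2 and compound 3, give numbers within the scatter of each other, which suggests that a further aromatic extension changes little.

The account therefore expects for compound 4 a step from a 1.3-fold lower number from compound 2 to compound 4 (0.12 log units; within the scatter) that stays within or only just beyond the scatter. Compound 4 is estimated at 1200 nM, with a range from 400 nM to 4000 nM.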

Compound 4, half-maximal inhibitory concentration: 110 nM
Compound 4: the middle estimate sits 11-fold (1.04 log units) above what was measured, outside the stated range (below it).
By their numbers in this assay, from the lowest: compound 4; then compounds 2 and 3 (each within the scatter of the next). At a limit, above all of these: compound 1.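

In this assay, for the compounds shown here, putting 3-(methylsulfanyl)phenyl in place of isopropyl on an aromatic carbon gives a 15-fold lower number from compound 2 to compound 4 (1.16 log units; beyond the scatter), the first step in this set that can be read at a single position. It shows that this place, meta to a large group, is not indifferent to what it carries: the entering group brings one six-membered aromatic ring of carbon only and a sulfur atom, and the number moves well beyond the scatter. Nothing given here accounts for the size of this step.

The compounds shown leave open whether the added ring alone carries the step or whether the methylsulfanyl group on it is needed, a question that a plain phenyl at this place would help to settle. Also open, going by these compounds, is how far the outer group can be varied, for instance by a methoxy group, an amine, a carboxylic acid or a longer chain on the added ring, and whether the number would hold, rise or fall further.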